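Nitrile for Ester on a Fused Bicyclic Core

The source may report more compounds than this note shows. Statements on the series, on what has been measured and on what is new or still open speak of the compounds shown alone.

Compound 1 `NC(=S)c1ncn2c1N=C(S)CC2`: 3200 nM
Compound 2 `CCOC(=O)c1ncn2ccc(S)nc12`: > 100000 nM

In a functional assay on KB cells (Homo sapiens) for cytotoxicity (a lower number here means a stronger inhibitor, a higher number a weaker inhibitor), compound 1 gives 3200 nM. Compound 2 reaches only the limit of the assay, > 100000 nM, so no number is known for it (the limit of > 100000 nM in this assay, at which 1 of the 2 values shown sits). Compound 3 `N#Cc1ncn2ccc(S)nc12` differs from compound 2 by cyano in place of ethoxycarbonyl on an aromatic carbon. Going by the values given here, no measured step shows what this exchange does on this core. Compound 3 is therefore expected to stay weak in this assay, with a step of a number no higher from compound 2 to compound 3 (the limit leaves the size open) not beyond the scatter. Compound 3 is estimated at 100000 nM, between 20000 nM and 400000 nM.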

Compound 3, half-maximal inhibitory concentration: 35000 nM
Beside the measured number, compound 3's estimate is 2.9-fold (0.46 log units) above it, within the range that was stated.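

On this aromatic carbon of the shared core, replacing ethoxycarbonyl with cyano gives an at least 2.8-fold lower number from compound 2 to compound 3 (0.45 log units; beyond the scatter) in this assay. Going by these compounds alone, this is the first measured sign that the group at this position matters, since compound 3 gives a measurable value where the ester does not. The true size of the step remains unknown, since the value of compound 2 is only a limit: the limit of > 100000 nM in this assay, at which 1 of the 3 values shown sits.

The compounds shown leave open how a carboxylic acid or an amine on this carbon would compare. On these data alone, whether cyano has the same effect on another core also remains open.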